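This account rests on a few compounds, and the source may have more. Where it says the series, first, only, none or still open, it means among the compounds named here.

Measured compounds in a physicochemical assay for solubility, with a stated time of 18 h, at pH 7.4; a lower number here means a less soluble compound, a higher number a more soluble compound:
- compound 1, `c1ccc(Oc2ccc3c(NCCCNCc4ccco4)ccnc3c2)cc1`: 14500 nM
- compound 2, `COc1cccc(CNCCCNc2ccnc3cc(Oc4ccc(F)cc4)ccc23)c1O`: 14500 nM
- compound 3, `CCC(CC)c1ccc2c(NCCCNCc3cccc(OC)c3O)ccnc2c1`: 4200 nM

Compound 3 gives the lowest number of the three in this assay, standing a 3.5-fold lower number from compound 2 to compound 3 (0.54 log units; beyond the scatter) below compound 2, and the same distance below compound 1, both beyond the scatter. Compound 1 and compound 2 give the same number, so their difference in the aryl ether part shows nothing in this assay.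

Compound 4, `COc1cccc(CNCCCNc2ccnc3cc(Oc4ccccc4)ccc23)c1O`, differs from compound 3 in one place: phenoxy in place of pentan-3-yl on an aromatic carbon. The group that leaves carries no ring and no acceptor; the group that enters brings one six-membered aromatic ring of carbon only and one hydrogen-bond acceptor.

Among the measured compounds shown here, the step that bears on this is the one from compound 2 to compound 3, where 4-fluorophenoxy gave way to pentan-3-yl and the number fell, a 3.5-fold lower number from compound 2 to compound 3 (0.54 log units; beyond the scatter). The change from compound 3 to compound 4 undoes that change, with phenoxy rather than 4-fluorophenoxy entering. Compound 4 is also compound 2 with phenoxy in place of 4-fluorophenoxy, and compound 1 and compound 2 show that this pair of groups reads alike here. The number for compound 4 is therefore expected to rise, a 3.5-fold higher number from compound 3 to compound 4 (0.54 log units; beyond the scatter), back toward compound 2. Compound 4 is estimated at 14500 nM, within 7000 nM to 30000 nM.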

Compound 4, solubility: 14500 nM
Beside the measured number, compound 4's estimate shows no gap at the digits printed, and the stated range covers the measured number.
By their numbers in this assay, from the lowest: compound 3; then compounds 1, 2 and 4 (each within the scatter of the next).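

In this assay the step at this aromatic carbon now reads in the reverse direction as well, with phenoxy in place of pentan-3-yl giving a 3.5-fold higher number from compound 3 to compound 4 (0.54 log units; beyond the scatter). The fluoro on the phenoxy ring can now be read on its own, and hydrogen in its place gives no change at the digits printed from compound 2 to compound 4 (within the scatter); compound 1 and compound 2 differ in two places and could not show this. The other single change, 2-hydroxy-3-methoxyphenyl in place of furan-2-yl on a saturated chain carbon bound to an amine nitrogen, gives no change at the digits printed from compound 1 to compound 4 (within the scatter).

No measurement shown accounts for these steps. As far as these compounds go, the ring and the oxygen of phenoxy enter together, so whether the number follows one or the other stays open; cyclohexyl or methoxy at this aromatic carbon would separate them.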